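Thiophen-2-yl to 2-fluoropyridin-4-yl: working notes

The source may report more compounds than this note shows. Statements on the series, on what has been measured and on what is new or still open speak of the compounds shown alone.

Measured in a toxicity assay on MT4 cells (Homo sapiens) for cytotoxicity, read by MTT assay, with a stated time of 5 days; on this read-out lower numbers stand for higher toxicity in this test and higher numbers for lower toxicity in this test:
- Compound 1 `Cc1cnc(Nc2ccc(C#N)cc2)nc1Nc1c(F)cc(-c2ccco2)cc1F` gives 8100 nM
- Compound 2 `Cc1cnc(Nc2ccc(C#N)cc2)nc1Nc1c(F)cc(-c2cccs2)cc1F` gives 8000 nM

For the measured compounds named here, compound 2 has only one neighbour on these numbers, compound 1, and the two lie within the scatter of each other. The next structure is compound 3 `Cc1cnc(Nc2ccc(C#N)cc2)nc1Nc1c(F)cc(-c2ccnc(F)c2)cc1F`, which carries 2-fluoropyridin-4-yl in place of thiophen-2-yl on an aromatic carbon.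

Going by the values given here, one measured step bears on this change, at the same place on the shared core. That step, a 1.0-fold lower number from compound 1 to compound 2 (0.01 log units; within the scatter), exchanged one five-membered aromatic ring for another and stayed within the scatter. Among the compounds with values here, it is thin evidence, as no measured compound has a six-membered aromatic ring at this place, so the outcome of that exchange remains untested. On this basis, no shift beyond the scatter is expected in this assay, and the direction is left open. The expected move is a 1.1-fold higher number from compound 2 to compound 3 (0.05 log units; within the scatter) and nothing firmer. For compound 3 the estimated value is 9000 nM, with an expected range from 3500 nM to 25000 nM.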

Compound 3, half-maximal cytotoxic concentration: 167000 nM
The estimate for compound 3 lay 19-fold (1.27 log units) below the measured number, outside the stated range (above it).
By their numbers in this assay, from the lowest: compounds 2 and 1 (each within the scatter of the next); then compound 3.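

In this assay this position turns out to be able to move the read-out: there is a 21-fold higher number from compound 2 to compound 3 (1.32 log units; beyond the scatter) and likewise a 21-fold higher number from compound 1 to compound 3 (1.31 log units; beyond the scatter) in the direction of lower toxicity in this test, whereas the exchange of one five-membered aromatic ring for the other gave only a 1.0-fold lower number from compound 1 to compound 2 (0.01 log units; within the scatter) and stayed within the scatter. Both large steps end at compound 3 and start from compounds within the scatter of each other, so the shift appears with 2-fluoropyridin-4-yl in place of either five-membered ring, although these three compounds cannot separate the six-membered ring from its fluorine or its ring nitrogen. No measurement available for this series offers an explanation for the shift.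

On these data alone, whether a plain phenyl ring or a pyridin-4-yl group without the fluorine would follow compound 3 or stay with the five-membered rings remains open. Also open, as far as these compounds go, is where an amine, a carboxylic acid or a longer alkyl chain on the six-membered ring at this place would fall on this read-out.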